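A few compounds are considered here, and "the series" means these few. Any claim that something is new, unique, unknown or untested is made for them only; others in the source may bear on it.

Series notes. The shared core carries an amide-type nitrogen bearing a variable aryl group. Compound 1 `COc1ccc(NC(=O)c2cccc(/C=C3\CC(=O)N(c4ccccc4)C3=O)c2)cc1` carries 4-methoxyphenyl there; in an ADME assay on NCM460 cells (Homo sapiens) for cytotoxicity, read by MTT assay, with a stated time of 72 h (on this read-out higher numbers stand for weaker inhibition and lower numbers for stronger inhibition), compound 1 gives only a limit, > 100000 nM. Compound 2 `O=C(Nc1cccc(F)c1)c1cccc(/C=C2\CC(=O)N(c3ccccc3)C2=O)c1` carries 3-fluorophenyl on the same nitrogen; in this assay compound 2 likewise reaches only a limit, > 100000 nM. The step that the two limits leave unreadable from compound 1 to compound 2 cannot be read in size because both ends sit at the limit of > 100000 nM in this assay, at which 2 of the 2 values shown sit. Where compound 2 stands on the numbers shown is thus the limit itself, with the single further value also a limit.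

Compound 3 `CCOc1ccc(NC(=O)c2cccc(/C=C3\CC(=O)N(c4ccccc4)C3=O)c2)cc1` is to be measured in this assay. It differs from compound 2 in 4-ethoxyphenyl in place of 3-fluorophenyl on an amide-type nitrogen. Within the data shown here, the only measured step that bears on this position, a step that the two limits leave unreadable from compound 1 to compound 2, gave no readable size, and neither a 4-methoxyphenyl nor a 3-fluorophenyl on this nitrogen brought the value within the readable range. No direction can be drawn from the numbers. The expected step that the limit leaves unreadable from compound 2 to compound 3 is therefore none beyond the scatter, with the likeliest outcome again a limit. Compound 3 is estimated at 150000 nM in this assay, within 50000 nM to 500000 nM.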

Compound 3, half-maximal inhibitory concentration: > 100000 nM
Compound 3: a limit, no number; the forecaster's own chance of this, stated with the estimate: 85%; the middle value lies beyond the limit too.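

No step among compound 1, compound 2 and compound 3 can be read in size, because all three stop at the same limit of the assay: the limit of > 100000 nM in this assay, at which 3 of the 3 values shown sit.

The compounds shown leave open whether any aryl group on this amide-type nitrogen would give a readable value in this assay.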